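Will Compound 4 Keep the Long Half-Life of Compound 3?

A few compounds are considered here, and "the series" means these few. Any claim that something is new, unique, unknown or untested is made for them only; others in the source may bear on it.

In an ADME assay on microsomes from liver (Rattus norvegicus) for metabolic stability (on this read-out lower numbers stand for a shorter-lived compound and higher numbers for a longer-lived compound), compound 1 `CN1C(=O)COc2nc(Nc3cc4c(cn3)ncn4CC3CC3)ccc21` gives 0.65 h and compound 2 `CN1C(=O)COc2cc(Nc3cc4c(cc3OC(F)(F)F)ncn4CC3CC3)cnc21` gives 0.55 h. Compound 3 `Cc1nnc(-c2ccc(Nc3cc(C)c4ncn(CC5CC5)c4n3)nc2)o1` is recorded as > 1.66 h, which is a limit of the assay and not a number. Compound 4 `Cc1cc(Nc2ccc(-n3ccnc3)cn2)nc2c1ncn2CC1CC1` changes one group of compound 3, with 1H-imidazol-1-yl in place of 5-methyl-1,3,4-oxadiazol-2-yl on an aromatic carbon. Among the compounds with values here, no measured pair of compounds shows what such a swap does, so the expectation leans towards the shorter readings, such as compound 1 at 0.65 h. A moderate shortening is expected, an estimated step of an at least 1.8-fold lower number from compound 3 to compound 4 (0.26 log units; that floor lies within the scatter). For compound 4 the estimated half-life in this assay is 0.9 h, with an expected range of 0.4 h to 1.7 h.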

Compound 4, half-life: 0.45 h
Beside the measured number, compound 4's estimate is 2.0-fold (0.30 log units) above it; the measured number falls inside the stated range.
By their numbers in this assay, from the lowest: compounds 4, 2 and 1 (each within the scatter of the next). At a limit, above all of these: compound 3.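

Within the data shown here, this gives the first measured reading of a swap at this position. In this assay, putting 1H-imidazol-1-yl in place of 5-methyl-1,3,4-oxadiazol-2-yl gives an at least 3.6-fold lower number from compound 3 to compound 4 (0.56 log units; beyond the scatter), so the choice between these two five-membered aromatic rings matters for half-life. As far as these compounds go, the true size of the step stays unknown because compound 3 is recorded only at a limit of the assay: the limit of > 1.66 h in this assay, at which 1 of the 4 values shown sits.

The compounds shown leave open how a nitrile or a simple amide would fare on this carbon, para to a large group. They also leave open whether the same swap would act alike on another core.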